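Methoxy in place of nitro on compound 1

The source may hold more compounds than are shown below. What is called first, only, known or untested is meant among the compounds shown, and "the series" means these compounds.

compound 1 `O=C(NNC(=O)c1cc([N+](=O)[O-])c[nH]1)Nc1ccc([N+](=O)[O-])cc1` gives 211000 nM
compound 2 `Cn1cc([N+](=O)[O-])cc1C(=O)NNC(=O)Nc1ccc([N+](=O)[O-])cc1` gives 402000 nM
compound 3 `Cn1cc([N+](=O)[O-])cc1C(=O)NNC(=S)Nc1ccc(F)cc1` gives 662000 nM

In an ADME assay on Vero cells (Chlorocebus sabaeus) for cytotoxicity, read by MTT assay, with a stated time of 72 h (on this read-out higher numbers stand for weaker inhibition and lower numbers for stronger inhibition), compound 1 gives 211000 nM and stands at the low end of the three numbers. For the measured compounds named here, the only comparison made at a single place is a 1.9-fold higher number from compound 1 to compound 2 (0.28 log units; within the scatter) and it leaves compound 1 level with its nearest neighbour. Only compound 3 stands clearly apart from compound 1 on the higher side.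

Compound 4 `COc1ccc(NC(=O)NNC(=O)c2cc([N+](=O)[O-])c[nH]2)cc1` keeps the core of compound 1 and changes one group: methoxy in place of nitro on an aromatic carbon with methoxy in place of nitro on an aromatic carbon, para to a large group. Going by the values given here, no measured step covers this change, since the step above concerns methyl in place of hydrogen on an aromatic nitrogen. Compound 3 (662000 nM) also lacks the nitro on that ring but differs elsewhere as well, so it offers only a weak hint of an upward move. A small rise is therefore expected, an estimated 1.6-fold higher number from compound 1 to compound 4 (0.21 log units; within the scatter) in this assay at most modest in size. Compound 4 is estimated at 340000 nM with an expected range from 150000 nM to 780000 nM in this reading.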

Compound 4, half-maximal inhibitory concentration: 401000 nM
For compound 4 the middle estimate is 1.2-fold (0.07 log units) below the measured one; low and high end bracket the measured number.
By their numbers in this assay, from the lowest: compounds 1, 4, 2 and 3 (each within the scatter of the next, the first and the last beyond it).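

In this assay, for the compounds shown here, putting methoxy in place of nitro on an aromatic carbon, para to a large group, gives a 1.9-fold higher number from compound 1 to compound 4 (0.28 log units; within the scatter) and so provides the first direct reading of a change at this position. Compound 4 stays level with compound 1 even though the nitro on this six-membered aromatic ring of carbon only has gone, so this nitro is not required for a reading in this range. Nothing available explains why this exchange of groups leaves the reading within the scatter.

The compounds shown leave open whether an amine or a carboxylic acid on the same aromatic carbon would also stay level with compound 1 or would move beyond the scatter. Going by these compounds, it also remains open whether methoxy at this position would stay level when the aromatic nitrogen carries methyl, as it does in compound 2.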